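Replacing a methoxyphenyl amide with a difluorophenyl amide

The compounds below may be only part of what the source reports. "The series", "measured", "known", "first", "only" and "open" are said of these compounds alone.

Compound 1 `COc1ccc(NC(=O)[C@H]2CN(C)C[C@@H]2c2ccc(/C=C/C(=O)Nc3ccccc3N)cc2)cc1` and compound 2 `CC(C)c1ccc(NC(=O)[C@H]2CN(C)C[C@@H]2c2ccc(/C=C/C(=O)Nc3ccccc3N)cc2)cc1` share one core. In an in vitro ADME assay on microsomes from liver (Homo sapiens) for pharmacokinetics, read by LC-MS, with a stated time of 10 min, tested at 1 uM (a higher number here means faster removal of the compound, a lower number slower removal), compound 1 gives 14 mL/min/kg and compound 2 gives 10 mL/min/kg; compound 1 shows the higher of the two numbers, but the step of a 1.4-fold lower number from compound 1 to compound 2 (0.15 log units; within the scatter) lies within the scatter. Compound 3 `CN1C[C@H](C(=O)Nc2ccc(F)cc2F)[C@@H](c2ccc(/C=C/C(=O)Nc3ccccc3N)cc2)C1` differs from compound 1 by 2,4-difluorophenyl in place of 4-methoxyphenyl on an amide-type nitrogen. Among the measured compounds shown here, the only measured step concerns a different group, so no step bears directly on this change, and none beyond the scatter is expected: a 1.2-fold lower number from compound 1 to compound 3 (0.07 log units; within the scatter). Compound 3 is therefore estimated at 12 mL/min/kg, with a range from 6 mL/min/kg to 24 mL/min/kg.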

Compound 3, clearance: 12 mL/min/kg
The estimate for compound 3 equals the measured number at the digits printed; the measured number falls inside the stated range.
By their numbers in this assay, from the lowest: compounds 2, 3 and 1 (each within the scatter of the next).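

On the amide-type nitrogen, 2,4-difluorophenyl in place of 4-methoxyphenyl gives a 1.2-fold lower number from compound 1 to compound 3 (0.07 log units; within the scatter) in this assay and in place of 4-isopropylphenyl gives a 1.2-fold higher number from compound 2 to compound 3 (0.08 log units; within the scatter) in the same assay. This position has therefore now carried three substituted phenyl groups, two of them differing from each other in more than one ring substituent, with all three numbers within the scatter of one another. Nothing at hand explains these numbers. Open, as far as these compounds go, is whether a pyridine ring, a carboxylic acid or a longer alkyl chain on this nitrogen would also stay within that scatter.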